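The source may hold more compounds than are shown below. What is called first, only, known or untested is meant among the compounds shown, and "the series" means these compounds.

Measured in a functional assay on PC-3 cells (Homo sapiens) for cytotoxicity; on this read-out lower numbers stand for stronger inhibition and higher numbers for weaker inhibition:
- compound 1 `COc1ccc2nc(NC(=O)CCCCC(=O)NO)sc2c1`: 15.3 ug/mL
- compound 2 `Cc1ccc2nc(NC(=O)CCCCC(=O)NO)sc2c1`: 6.23 ug/mL
- compound 3 `O=C(CCCCCCC(=O)Nc1nc2ccc([N+](=O)[O-])cc2s1)NO`: 1.28 ug/mL

Compound 3 holds the lowest number of the three. Compound 4 `O=C(CCCCC(=O)Nc1nc2ccc([N+](=O)[O-])cc2s1)NO` keeps its aromatic substituent and alters the chain: hydroxycarbamoyl in place of 2-(hydroxycarbamoyl)ethyl on a saturated chain carbon, four bonds along the chain from a carbonyl carbon. Among the compounds with values here, the resulting chain is the one found in compound 1 and compound 2. Within the data shown here, no measured step covers this change. Among the measured compounds shown here, the only measured step, a 2.5-fold lower number from compound 1 to compound 2 (0.39 log units; beyond the scatter), concerns an aromatic substituent and bears on it only indirectly. It shows that numbers on this chain can still move. The chain of compound 4 is also that of compound 2, at 6.23 ug/mL, so a higher number in this assay is expected, though not with certainty. The expected step is a 2.3-fold higher number from compound 3 to compound 4 (0.37 log units; beyond the scatter). For compound 4 the estimate is 3 ug/mL, with an expected range of 1 ug/mL to 9 ug/mL.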

Compound 4, half-maximal inhibitory concentration: > 30 ug/mL
Compound 4 was reported as a limit; the forecaster's own chance of this, stated with the estimate: 5%; middle value at least 10-fold (1.00 log units) away from the limit.
By their numbers in this assay, from the lowest: compound 3; then compound 2; then compound 1. At a limit, above all of these: compound 4.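

In this assay compound 4 is reported only as a limit: the limit of > 30 ug/mL in this assay, at which 1 of the 4 values shown sits. With nitro on the shared core, hydroxycarbamoyl in place of 2-(hydroxycarbamoyl)ethyl on a saturated chain carbon, four bonds along the chain from a carbonyl carbon, gives a large step: an at least 23-fold higher number from compound 3 to compound 4 (1.36 log units; beyond the scatter). On this chain, nitro in place of methyl gives an at least 4.8-fold higher number from compound 2 to compound 4 (0.68 log units; beyond the scatter), while nitro in place of methoxy gives an at least 1.9-fold higher number from compound 1 to compound 4 (0.29 log units; that floor lies within the scatter), so this last step cannot be read. Going by these compounds, whether methyl or methoxy responds to the chain change as nitro does stays open. So does the outcome for a longer chain, or for an amine on the aromatic carbon.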